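Phenyl in place of ethyl: exposure notes

The source may hold more compounds than are shown below. What is called first, only, known or untested is meant among the compounds shown, and "the series" means these compounds.

In an ADME assay on the whole organism (plasma, strain 129/SvEvBrd x C57BL/6) for pharmacokinetics, with Mus musculus as the target, at a dose of 10 mg/kg by the oral route (on this read-out higher numbers stand for higher exposure at the dose given and lower numbers for lower exposure), compound 1 (`CC(=O)c1nc([C@@H](O)[C@H](O)[C@H](O)CO)c(C)[nH]1`) gives 2640 ng.h/mL and compound 2 (`CCc1[nH]c(C(C)=O)nc1[C@@H](O)[C@H](O)[C@H](O)CO`) gives 1650 ng.h/mL, so compound 2 stands within the scatter of compound 1. Compound 3 (`CC(=O)c1nc([C@@H](O)[C@H](O)[C@H](O)CO)c(-c2ccccc2)[nH]1`) has phenyl in place of ethyl on an aromatic carbon. Among the measured compounds shown here, the only measured step, a 1.6-fold lower number from compound 1 to compound 2 (0.20 log units; within the scatter), is a weak guide, as it involves methyl in place of hydrogen and no measured compound carries phenyl. The estimated change is a 1.5-fold lower number from compound 2 to compound 3 (0.18 log units; within the scatter), with no step beyond the scatter expected. For compound 3 the expected value is 1100 ng.h/mL, with an estimated range of 300 ng.h/mL to 3500 ng.h/mL.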

Compound 3, area under the concentration-time curve: 3520 ng.h/mL
The estimate for compound 3 lay 3.2-fold (0.51 log units) below the measured number, and the stated range ends below it.
By their numbers in this assay, from the lowest: compounds 2, 1 and 3 (each within the scatter of the next, the first and the last beyond it).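

A bulky aromatic ring is accepted on this aromatic carbon without any loss of exposure in this assay: the series shows a 2.1-fold higher number from compound 2 to compound 3 (0.33 log units; beyond the scatter) as its first step beyond the scatter. The replacement of methyl by phenyl gives a 1.3-fold higher number from compound 1 to compound 3 (0.12 log units; within the scatter) and so does not separate those two compounds, which means the gain holds only against ethyl. Nothing at hand explains this difference.

Open, as far as these compounds go, is whether a pyridyl ring, a substituted phenyl or an amine on this carbon would keep exposure. Also open, from the compounds shown here alone, is whether phenyl would do the same with the acetyl group replaced by a carboxylic acid.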